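The source may hold more compounds than are shown below. What is called first, only, known or untested is meant among the compounds shown, and "the series" means these compounds.

In a functional assay on U-87MG ATCC cells for cytotoxicity against U-87 MG (Homo sapiens), read by colorimetric assay and MTT assay (a lower number here means a stronger inhibitor, a higher number a weaker inhibitor), compound 1 `CCOC(=O)Cn1c(=O)c(-c2ccc(OC)cc2)cc2c(OC)cc(OC)cc21` gives 10000 nM and compound 2 `COc1ccc(-c2cc3c(OC)cc(OC)cc3n(CC(=O)OCc3ccccc3)c2=O)cc1` gives 10000 nM, so compound 2 stands level with compound 1. Compound 3 `COc1ccc(-c2cc3c(OC)cc(OC)cc3n(CCC#N)c2=O)cc1` differs from compound 2 by cyanomethyl in place of benzyloxycarbonyl on a saturated chain carbon bound to an aromatic nitrogen. Within the data shown here, the only measured step in this side chain is no change at the digits printed from compound 1 to compound 2 (within the scatter), and no measured compound carries a nitrile. No shift beyond the scatter is therefore expected in this assay, in either direction. The estimated change is no change at the digits printed from compound 2 to compound 3 (within the scatter). Compound 3 is expected at 10000 nM, with an estimated range of 4000 nM to 30000 nM.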

Compound 3, half-maximal inhibitory concentration: 10000 nM
Compound 3: the middle estimate sits on the measured number at the digits printed, and the stated range covers the measured number.
By their numbers in this assay, from the lowest: compounds 1, 2 and 3 (each within the scatter of the next).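

In this assay, cyanomethyl in place of benzyloxycarbonyl on a saturated chain carbon bound to an aromatic nitrogen gives no change at the digits printed from compound 2 to compound 3 (within the scatter), and cyanomethyl in place of ethoxycarbonyl gives no change at the digits printed from compound 1 to compound 3 (within the scatter). The number at this position therefore does not depend on an ester: a nitrile side chain with no ring and only 3 heavy atoms reads the same. No measurement at hand offers an explanation for this.

Still open, from the compounds shown here alone, is whether any group here moves the number: a primary amine, a carboxylic acid or a longer chain could test that.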